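The compounds below may be only part of what the source reports. "The series", "measured", "known", "first", "only" and "open" are said of these compounds alone.

Measured in an ADME assay on a cell-free system (plasma, Rattus norvegicus) for protein binding:
compound 1 `CNc1nccc(N2CC[C@H](NC(=O)Nc3ccc(Cl)c(C(F)(F)F)c3)C2)n1` gives 99.7%
compound 2 `Nc1nccc(N2CC[C@H](NC(=O)Nc3ccc(Cl)c(C(F)(F)F)c3)C2)n1` gives 99.4%
compound 3 `CCNc1nccc(N2CC[C@H](NC(=O)Nc3ccc(Cl)c(C(F)(F)F)c3)C2)n1` gives 99.9%

Compound 1 stands second highest of the three in unbound fraction: a 2.0-fold higher unbound fraction from compound 1 to compound 2 (0.30 log units; within the scatter) lies within the scatter, while a 3.0-fold lower unbound fraction from compound 1 to compound 3 (0.48 log units; beyond the scatter) and a 6.0-fold lower unbound fraction from compound 2 to compound 3 (0.78 log units; beyond the scatter) are modest steps beyond it.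

Compound 4 `CNc1nccc(N2CC[C@H](NC(=O)Nc3ccc(CN4CCC4)c(C(F)(F)F)c3)C2)n1` differs from compound 1 at another place: (azetidin-1-yl)methyl in place of chloro on an aromatic carbon. All three measured steps concern the nitrogen on the aromatic ring of the core, not the six-membered carbon-only ring, so none bears directly on this change; the series gives no anchor for it. The expectation is therefore a step of uncertain size in this assay with a wide range, weighted toward a higher unbound fraction, a 3.3-fold higher unbound fraction from compound 1 to compound 4 (0.52 log units; beyond the scatter). Compound 4 is estimated at 99%, between 97% and 99.7%.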

Compound 4, plasma protein binding: 89.2%
For compound 4 the middle estimate is 11-fold (1.03 log units) (unbound fraction) below the measured one, and the stated range ends above it.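

In this assay, (azetidin-1-yl)methyl in place of chloro on this aromatic carbon gives a 36-fold higher unbound fraction from compound 1 to compound 4 (1.56 log units; beyond the scatter), the largest step shown in the series. This carbon therefore moves the read-out further than the nitrogen substituents do, where the widest step is a 6.0-fold lower unbound fraction from compound 2 to compound 3 (0.78 log units; beyond the scatter). Nothing available here accounts for the size of the step.

Open, from the compounds shown here alone, is whether a plain methyl, a longer-chain amine or a carboxylic acid on this carbon would shift the read-out similarly. Also open, going by these compounds, is whether the hydrogen and ethyl variants of compound 2 and compound 3 keep their order with (azetidin-1-yl)methyl present.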